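The source may hold more compounds than are shown below. What is called first, only, known or untested is meant among the compounds shown, and "the series" means these compounds.

Measured in an ADME assay on HOS cells (Homo sapiens) for cytotoxicity; on this read-out lower numbers stand for stronger inhibition and higher numbers for weaker inhibition:
Compound 1 `O=C1c2ccc(O)c(O)c2C(=O)N1Cc1ccc(F)cc1`: "not determined" (no result reported)
Compound 2 `O=C1c2ccc(O)c(O)c2C(=O)N1Cc1cccc(Br)c1`: 11400 nM
Compound 3 `O=C1c2ccc(O)c(O)c2C(=O)N1Cc1cccc(I)c1`: 12000 nM

Compound 1 has no place on this scale, as no result was reported for it. Compound 4 `O=C1c2ccc(O)c(O)c2C(=O)N1Cc1ccc(F)c(Cl)c1` differs from it by one change: chloro in place of hydrogen on an aromatic carbon. This is chloro in place of hydrogen on an aromatic carbon. Among the measured compounds shown here, the only measured step is a 1.1-fold higher number from compound 2 to compound 3 (0.02 log units; within the scatter), a swap of iodo for bromo that stays within the scatter. It is a different change, and compound 1 offers no starting value, so no step size or direction can be expected. The nearest guides are compound 2 at 11400 nM and compound 3 at 12000 nM. In this assay the estimate for compound 4 is 11500 nM, with an expected range of 5000 nM to 26000 nM.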

Compound 4, half-maximal inhibitory concentration: 9540 nM
The estimate for compound 4 lay 1.2-fold (0.08 log units) above the measured number, and the stated range covers the measured number.
By their numbers in this assay, from the lowest: compounds 4, 2 and 3 (each within the scatter of the next).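

No new step can be read from compound 1 to compound 4: in this assay compound 1 gives "not determined" (no result reported). What the added chloro does to this read-out stays open, and nothing shown explains the numbers.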